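The source may report more compounds than this note shows. Statements on the series, on what has been measured and on what is new or still open speak of the compounds shown alone.

Compound 2 `COc1c(C)cnc(CN2CC(=O)N(CC(C)C)c3c(Cl)nc(N)nc32)c1C` gives the lowest number of the three measured in a functional assay on SK-BR-3 cells (Homo sapiens) for inhibition (a lower number here means a stronger inhibitor, a higher number a weaker inhibitor), with 10 nM. Compound 1 `Cc1cnc(CN2CC(=O)N(CC(C)C)c3c(Cl)nc(N)nc32)c(C)c1Br` gives 60 nM, and compound 3 `COc1c(C)cnc(CN2c3nc(N)nc(Cl)c3NC(=O)[C@H]2C)c1C` gives 220 nM. The one single-place step among these, a 6.0-fold lower number from compound 1 to compound 2 (0.78 log units; beyond the scatter), swaps a group on the aromatic ring and says nothing about the amide-type nitrogen in the ring.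

Compound 4 `COc1c(C)cnc(CN2CC(=O)N(C(C)C)c3c(Cl)nc(N)nc32)c1C` differs from compound 2 at that nitrogen: isopropyl in place of isobutyl on an amide-type nitrogen in a ring. Among the compounds with values here, no measured step bears directly on this change. Compound 3 carries a different group on the ring and a methyl on the ring carbon, so its gap to compound 2 cannot be traced to one place. The change removes one carbon from a short branched chain, and with no guide in the data a small loss, or no change beyond the scatter, is the most cautious expectation, a step of a 2.5-fold higher number from compound 2 to compound 4 (0.40 log units; beyond the scatter). For compound 4 in this assay the expected value is 25 nM, within a range from 8 nM to 80 nM.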

Compound 4, half-maximal inhibitory concentration: 20 nM
For compound 4 the middle estimate is 1.3-fold (0.10 log units) above the measured one, and the stated range covers the measured number.
By their numbers in this assay, from the lowest: compounds 2 and 4 (each within the scatter of the next); then compound 1; then compound 3.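

In this assay, within the data shown here, the step of a 2.0-fold higher number from compound 2 to compound 4 (0.30 log units; within the scatter) is the first direct reading of this position, the amide-type nitrogen in a ring. Isobutyl and isopropyl cannot be told apart here, so taking one carbon out of this short branched chain leaves the number within the usual scatter of repeated measurements. No supporting data offer an explanation for this result.

Both groups are small branched carbon chains, so this single pair shows only that these two are interchangeable in this assay, not how far the position would accept something different. From the compounds shown here alone, how the number would respond to a longer chain such as n-hexyl, to a cyclohexyl ring, or to a chain ending in an amine or a carboxylic acid remains open.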